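This account rests on a few compounds, and the source may have more. Where it says the series, first, only, none or still open, it means among the compounds named here.

Series notes. Compound 1 `O=C(c1cccnc1)c1cc(Cl)cc(Cl)c1O` gives 28800 nM in a functional assay on IMR-32 cells (Homo sapiens) for cytotoxicity, read by sulforhodamine B assay, with a stated time of 48 h; on this read-out lower numbers stand for stronger inhibition and higher numbers for weaker inhibition. Compound 2 `O=C(c1cccnc1)c1cc(Cl)ccc1O` gives 19500 nM in this assay; the change between them is hydrogen in place of chloro on an aromatic carbon and it made the step of a 1.5-fold lower number from compound 1 to compound 2 (0.17 log units; within the scatter). For the measured compounds named here, compound 3 `C=CCOc1ccc(Cl)cc1C(=O)c1cccnc1` gives 91000 nM in this assay, and the step of a 4.7-fold higher number from compound 2 to compound 3 (0.67 log units; beyond the scatter) leaves compound 3 with the highest number of the three measured so far. The difference between the core of compound 1 and the core of compound 3 is not broken down here.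

Compound 4 `C=CCOc1ccccc1C(=O)c1cccnc1` remains to be measured. It differs from compound 3 by hydrogen in place of chloro on an aromatic carbon. This is the same kind of change as that from compound 1 to compound 2, but not the same: in compound 1 the leaving chloro sits ortho to a hydroxy group and meta to a chloro group, whereas in compound 3 it sits para to an allyloxy group, both sites being meta to a group of 8 heavy atoms. Going by the values given here, the one earlier occurrence gave a 1.5-fold lower number from compound 1 to compound 2 (0.17 log units; within the scatter), a step inside the scatter, and with only that single precedent a similarly small step is expected here, a 1.3-fold lower number from compound 3 to compound 4 (0.11 log units; within the scatter). On that basis compound 4 is expected to give 70000 nM in this assay, with a range from 30000 nM to 200000 nM.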

Compound 4, half-maximal inhibitory concentration: 44000 nM
Beside the measured number, compound 4's estimate is 1.6-fold (0.20 log units) above it; the range from low to high includes it.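

In this assay, hydrogen in place of chloro on the aromatic carbon gives a 2.1-fold lower number from compound 3 to compound 4 (0.32 log units; beyond the scatter), and the comparison with the earlier occurrence of this change on a different core stands as follows: the same change on two cores in this assay, a 1.5-fold lower number (0.17 log units; within the scatter) from compound 1 to compound 2 and a 2.1-fold lower number (0.32 log units; beyond the scatter) from compound 3 to compound 4, 1.4-fold (0.15 log units) apart, within the scatter of two such steps.

The change therefore carries from the core of compound 1 to the core of compound 3 with no difference that can be claimed between the two steps, even though only the newer step lies beyond the scatter. This rests on two pairs in a single cytotoxicity read-out, so it does not show that the change would behave alike on any further core, and it gives no reason for the size of either step.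

Open, on these data alone, is whether another group at the carbon para to the allyloxy group, such as an amine or a methoxy group, would move the number as hydrogen does. Also open, as far as these compounds go, is how a longer chain or a carboxylic acid on the oxygen in place of allyl would behave with and without the chloro.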